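Stability Read-Out Across One Side-Chain Swap

The compounds below may be only part of what the source reports. "The series", "measured", "known", "first", "only" and "open" are said of these compounds alone.

compound 1 `CC1(C(=O)NCCSc2nonc2/C(=N/O)Nc2ccc(F)c(C(F)F)c2)CCN1` - 0.268 h
compound 2 `O=C(NCCSc1nonc1/C(=N/O)Nc1ccc(F)c(C(F)F)c1)C1CS(=O)(=O)C1` - 0.245 h
compound 3 `N#CCC(=O)NCCSc1nonc1/C(=N/O)Nc1ccc(F)c(C(F)F)c1` - 0.278 h

In an ADME assay on microsomes from liver (Mus musculus) for metabolic stability (on this read-out lower numbers stand for a shorter-lived compound and higher numbers for a longer-lived compound), the three compounds lie within the usual scatter of each other, so compound 3 at 0.278 h holds no real rank among them. Compound 4 `CC(C)(O)CC(=O)NCCSc1nonc1/C(=N/O)Nc1ccc(F)c(C(F)F)c1` keeps the shared core and changes one group (1-hydroxy-1-methylethyl in place of cyano on a saturated chain carbon bound to a carbonyl carbon): 1-hydroxy-1-methylethyl in place of cyano on a saturated chain carbon bound to a carbonyl carbon. Within the data shown here, three measured steps bear on this, each swapping the group on a carbonyl carbon: a 1.1-fold lower number from compound 1 to compound 2 (0.04 log units; within the scatter) and a 1.0-fold higher number from compound 1 to compound 3 (0.02 log units; within the scatter) and a 1.1-fold higher number from compound 2 to compound 3 (0.05 log units; within the scatter) all stay within the scatter. None is this exact swap, but no step beyond the scatter is expected in this assay here. The expected step is a 1.0-fold lower number from compound 3 to compound 4 (0.01 log units; within the scatter) on these grounds. For compound 4 the estimated half-life is 0.27 h with a range from 0.15 h to 0.5 h as the expected spread.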

Compound 4, half-life: 0.175 h
For compound 4 the middle estimate is 1.5-fold (0.19 log units) above the measured one; the range from low to high includes it.
By their numbers in this assay, from the lowest: compounds 4, 2, 1 and 3 (each within the scatter of the next).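

In this assay, 1-hydroxy-1-methylethyl in place of cyano on a saturated chain carbon bound to a carbonyl carbon gives a 1.6-fold lower number from compound 3 to compound 4 (0.20 log units; within the scatter), and the comparisons with the other two compounds give a 1.4-fold lower number from compound 2 to compound 4 (0.15 log units; within the scatter) and a 1.5-fold lower number from compound 1 to compound 4 (0.19 log units; within the scatter). These steps are larger than the earlier ones, yet all still lie within the scatter, so an open chain carrying a hydroxy group also leaves the half-life without a real shift. No measurement here accounts for these steps. As far as these compounds go, whether an amine or a carboxylic acid at this place would give a step beyond the scatter remains open.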